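The source may hold more compounds than are shown below. What is called first, only, known or untested is meant among the compounds shown, and "the series" means these compounds.

Compound 3 `CN1CCN(C(=S)SCc2ccc(C(=O)Nc3ccccc3N)cc2)CC1` gives 84.4% in a functional assay on MGC-803 cells (Homo sapiens) for antiproliferative activity, read by CCK-8 assay, with a stated time of 72 h, tested at 8 uM (a lower number here means a weaker effect, a higher number a stronger effect of the compound at the concentration tested), the highest of the three measured numbers. The two other measured compounds carry an aromatic group on the amine nitrogen in the ring where compound 3 carries a methyl: compound 1 `Nc1ccccc1NC(=O)c1ccc(CSC(=S)N2CCN(c3ccc(Cl)cc3)CC2)cc1` gives 17.2% and compound 2 `N#Cc1ccc(N2CCN(C(=S)SCc3ccc(C(=O)Nc4ccccc4N)cc3)CC2)cc1` gives 37.6%. The step of a number 67.2 percentage points higher from compound 1 to compound 3 (beyond the scatter) and the step of a number 46.8 percentage points higher from compound 2 to compound 3 (beyond the scatter) both show that exchanging the aromatic group on that nitrogen for a methyl came with a large gain; the step of a number 20.4 percentage points higher from compound 1 to compound 2 (beyond the scatter) between the two aromatic groups was modest.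

Compound 4 `Nc1ccccc1NC(=O)c1ccc(CSC(=S)N2CCN(Cc3cccnc3)CC2)cc1` differs from compound 3 by pyridin-3-yl in place of hydrogen on a saturated chain carbon bound to an amine nitrogen in a ring, so that the methyl becomes a (pyridin-3-yl)methyl. Going by the values given here, none of the measured steps matches this change exactly: here the aromatic ring enters one bond away from the ring nitrogen rather than on it. The two large steps that bear on it both point the same way, from an aromatic group toward a methyl, and the new change runs in the opposite direction. A drop beyond the scatter is therefore expected, but smaller than those two steps, as an estimated a number 29.4 percentage points lower from compound 3 to compound 4 (beyond the scatter). Compound 4 is expected to give about 55%, within a range from 30% to 80%.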

Compound 4, a percentage reported as inhibition, at one concentration (the size of the read-out at that concentration, not a potency): 64.6%
For compound 4 the middle estimate is 9.6 percentage points below the measured one; low and high end bracket the measured number.
By their numbers in this assay, from the lowest: compound 1; then compound 2; then compound 4; then compound 3.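

In this assay an aromatic ring at this position does not have to cost most of the effect: with the pyridin-3-yl held on a saturated chain carbon bound to the amine nitrogen in the ring, the result is a number 19.8 percentage points lower from compound 3 to compound 4 (beyond the scatter) and this loss is only modest. The (pyridin-3-yl)methyl group also compares well with the aromatic groups set directly on that nitrogen, giving a number 27 percentage points higher from compound 2 to compound 4 (beyond the scatter) against the 4-cyanophenyl and a number 47.4 percentage points higher from compound 1 to compound 4 (beyond the scatter) against the 4-chlorophenyl, so this position accepts a larger group than methyl while keeping much of the read-out. No measurement available here explains these differences.

Because these last two steps swap both the kind of aromatic ring and the way it is attached, the compounds shown cannot separate the contribution of the pyridine ring from that of the added saturated carbon; a benzyl group or a pyridin-3-yl placed directly on the nitrogen would address that. Also open, from the compounds shown here alone, is how a longer chain, such as a 2-(pyridin-3-yl)ethyl, or a hydroxyethyl group would fare at this nitrogen.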